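Chloro to methyl in the amine-bearing series

This account rests on a few compounds, and the source may have more. Where it says the series, first, only, none or still open, it means among the compounds named here.

Measured so far in a functional assay on the whole organism for positive allosteric modulation, with Mus musculus as the target; on this read-out lower numbers stand for an effect already at smaller amounts and higher numbers for an effect only at larger amounts of compound:
- compound 1 `CCC(=O)N(c1ccc(Cl)c(Cl)c1)C1CCCC1O`: 0.4 mg/kg
- compound 2 `CCC(=O)N(c1ccc(Cl)cc1)C1CCCCC1N(C)C`: 35 mg/kg

Of these two numbers, compound 2 holds the higher, 35 mg/kg, and its gap to compound 1, at 0.4 mg/kg, lies beyond the scatter. The two compounds differ in more than one place, so this gap says nothing about any single change.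

Compound 3 `CCC(=O)N(c1ccc(C)cc1)C1CCCCC1N(C)C` carries methyl in place of chloro on an aromatic carbon, para to a large group (methyl in place of chloro on an aromatic carbon). Within the data shown here, no measured pair shows this exchange, so the expectation starts from compound 2 at 35 mg/kg. In this assay, no shift beyond the scatter is expected in either direction, and the estimated step is small: a 1.1-fold higher number from compound 2 to compound 3 (0.06 log units; within the scatter). For compound 3 the estimated value is 40 mg/kg, with an expected range from 15 mg/kg to 100 mg/kg.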

Compound 3, dose for half-maximal effect: > 50 mg/kg
Compound 3 gave a limit, no number; the forecaster's own chance of this, stated with the estimate: 15%; middle value at least 1.2-fold (0.09 log units) away from the limit.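

In this assay compound 3 gives a limit and not a number: the limit of > 50 mg/kg in this assay, at which 1 of the 3 values shown sits. Among these compounds, this is the first reading of 4-chlorophenyl to 4-methylphenyl on the shared core, and it comes out as an at least 1.4-fold higher number from compound 2 to compound 3 (0.15 log units; that floor lies within the scatter). Methyl on this aromatic carbon therefore gives no sign of a lower number than chloro, but the reading fixes only a floor for the step and not its true size.

As far as these compounds go, it remains open how far compound 3 lies past its limit. From the compounds shown here alone, it is also open whether another group in this place, such as fluoro, methoxy, trifluoromethyl or nitrile, would move the number beyond the scatter from that of compound 2.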